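Methyl for hydrogen on a phenolic oxygen in a chalcone series

The source may report more compounds than this note shows. Statements on the series, on what has been measured and on what is new or still open speak of the compounds shown alone.

Measured compounds:
- compound 1, `COc1ccc(/C=C/C(=O)c2ccc3occc3c2O)c(OC)c1OC`: 67.3%
- compound 2, `COc1ccc(/C=C/C(=O)c2ccc3occc3c2O)cc1`: 94.8%
- compound 3, `COc1cc(/C=C/C(=O)c2ccc3occc3c2O)ccc1O`: 45%

All three share one core and differ only in the groups carried on the outer aromatic ring. In an assay on isolated protein for inhibition of lysosomal alpha-glucosidase (Rattus norvegicus), read by spectrophotometry, with a stated time of 5 min, tested at 25 ug/mL (on this read-out lower numbers stand for less inhibition and higher numbers for more inhibition at the one concentration tested (going by the name of the read-out)), compound 2 gives 94.8%, compound 1 gives 67.3%, and compound 3 gives 45%. Compound 3 stands lowest of the three, and both gaps to the others are beyond the usual scatter, so its inhibition in this assay is the lowest number among the measured compounds.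

Compound 4, `COc1ccc(/C=C/C(=O)c2ccc3occc3c2O)cc1OC`, has not yet been measured. It differs from compound 3 in one place: methyl in place of hydrogen on an oxygen on an aromatic ring. Going by the values given here, no pair of measured compounds differs in exactly this way, so the size of this step cannot be read off directly. What can be said is that the two compounds bearing only methoxy groups on the outer ring, compound 2 and compound 1, both sit well above compound 3 in this assay.

On that basis compound 4 is expected to rise above compound 3, with a step of a number 25 percentage points higher from compound 3 to compound 4 (beyond the scatter). The estimate for compound 4 in this assay is 70%, within a range of 45% to 90%.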

Compound 4, a percentage reported as inhibition, at one concentration (the size of the read-out at that concentration, not a potency): 89.5%
Beside the measured number, compound 4's estimate is 19.5 percentage points below it; the measured number falls inside the stated range.
By their numbers in this assay, from the lowest: compound 3; then compound 1; then compounds 4 and 2 (each within the scatter of the next).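

In this assay, going by these compounds alone, methyl in place of hydrogen on an oxygen on an aromatic ring, the change from hydroxy to methoxy, gives a number 44.5 percentage points higher from compound 3 to compound 4 (beyond the scatter) and supplies the first direct reading of this change, which shows that on this pair the hydroxy goes with much less inhibition than the methoxy. The other two changes on the outer ring can now be read as well: methoxy in place of hydrogen on an aromatic carbon gives a number 5.3 percentage points lower from compound 2 to compound 4 (within the scatter) in this series, while hydrogen in place of methoxy on an aromatic carbon gives a number 22.2 percentage points higher from compound 1 to compound 4 (beyond the scatter) for the same comparison set. Nothing available explains why the hydroxy-to-methoxy change has this effect on inhibition.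

The compounds shown leave open whether a group larger than methyl on this oxygen, such as ethyl or a longer chain, would hold inhibition at the level of compound 4, or whether an amine in place of the oxygen would do the same. Going by these compounds, each reading also comes from a single concentration, so how these compounds rank in potency remains open.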